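The compounds below may be only part of what the source reports. "The series", "measured", "known", "first", "only" and "open" are said of these compounds alone.

Compound 1, `CCCc1cc(NC)c2cc(NC(=O)/C=C/c3ccc(C(F)(F)F)cc3)ccc2n1`: 1.5 nM
Compound 2, `CCc1cc(N)c2cc(NC(=O)/C=C/c3ccc(C(F)(F)F)cc3)ccc2n1`: 1.2 nM
Compound 3, `CCCc1cc(N)c2cc(NC(=O)/C=C/c3ccc(O)cc3)ccc2n1`: 1100 nM

In an assay on isolated protein for displacement of a labelled ligand from melanin-concentrating hormone receptor 1 (Homo sapiens) (a higher number here means a weaker inhibitor, a lower number a stronger inhibitor), compound 1 gives 1.5 nM, the second highest of the three numbers. Compound 2 gives 1.2 nM, which lies within the scatter of compound 1, so the two cannot be ordered. Within the data shown here, compound 3 gives 1100 nM, far beyond the scatter from compound 1; it differs from compound 1 in more than one place, so what its gap shows is only that these two compounds sit far apart.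

Compound 4, `CCCc1cc(N2CCCC2)c2cc(NC(=O)/C=C/c3ccc(C(F)(F)F)cc3)ccc2n1`, differs from compound 1 in one place: pyrrolidin-1-yl in place of methylamino on an aromatic carbon. Among the measured compounds shown here, no measured pair shows this change, so the expectation rests only on compound 1 and compound 2, which show that an amino and a methylamino group at this carbon both go with low numbers. Compound 4 is therefore expected to give 5 nM, within a range from 1 nM to 60 nM. That estimate means a step of a 3.3-fold higher number from compound 1 to compound 4 (0.52 log units; beyond the scatter), expected to be a modest rise in the number, near the edge of the scatter.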

Compound 4, half-maximal inhibitory concentration: 17 nM
For compound 4 the middle estimate is 3.4-fold (0.53 log units) below the measured one; the measured number falls inside the stated range.
By their numbers in this assay, from the lowest: compounds 2 and 1 (each within the scatter of the next); then compound 4; then compound 3.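

In this assay, among these compounds, pyrrolidin-1-yl in place of methylamino on this aromatic carbon, opposite the ring nitrogen, brings an 11-fold higher number from compound 1 to compound 4 (1.05 log units; beyond the scatter) and so gives the first readable single change at this position. The position is therefore not indifferent to the group it carries, and this larger ring-bearing amine goes with a clearly higher number, although compound 4 still gives 17 nM. Nothing available accounts for the size of this step.

The compounds shown leave open whether the rise follows the ring, the added heavy atoms or the lost hydrogen-bond donor, since all three change together in this one step. A dimethylamino or a piperidin-1-yl group on the same carbon would help to separate them.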